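Trifluoromethyl in Place of Methyl: What to Expect for Compound 4

A few compounds are considered here, and "the series" means these few. Any claim that something is new, unique, unknown or untested is made for them only; others in the source may bear on it.

Of the compounds shown here, three built on a shared core have been measured in an assay on mitochondria from L6 cells (Rattus norvegicus) for activation, with a stated time of 90 min; a lower number here means that less compound is needed, a higher number that more compound is needed for the effect. Compound 1 `FC(F)(F)c1ccccc1Nc1nc2nonc2nc1Nc1ccccc1C(F)(F)F` gives 1000 nM. Compound 2 `Fc1cccc(Nc2nc3nonc3nc2Nc2ccccc2F)c1` gives 190 nM. Compound 3 `Cc1ccccc1Nc1nc2nonc2nc1Nc1ccccc1F` gives 1100 nM, the highest of the three numbers; it lies within the scatter of compound 1 and beyond the scatter of compound 2. Among the measured compounds shown here, the single one-place step among the measured compounds is a 5.8-fold higher number from compound 2 to compound 3 (0.76 log units; beyond the scatter), with 2-methylphenyl in place of 3-fluorophenyl on a nitrogen on an aromatic ring.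

Compound 4 `Fc1ccccc1Nc1nc2nonc2nc1Nc1ccccc1C(F)(F)F` differs from compound 3 in one place: trifluoromethyl in place of methyl on an aromatic carbon. For the measured compounds named here, no measured pair sets a methyl against a trifluoromethyl, so the one recorded step concerns a different change and does not bear directly on this one. The closest guide is compound 1, which carries trifluoromethyl on both outer rings and gives 1000 nM, a number within the scatter of compound 3. On that basis the change is expected to bring no step beyond the scatter, and the step from compound 3 to compound 4 is estimated at a 1.2-fold lower number from compound 3 to compound 4 (0.06 log units; within the scatter). Compound 4 is therefore expected to give about 950 nM in this assay, in a range from 350 nM to 2600 nM.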

Compound 4, half-maximal effective concentration: 1400 nM
For compound 4 the middle estimate is 1.5-fold (0.17 log units) below the measured one, and the stated range covers the measured number.
By their numbers in this assay, from the lowest: compound 2; then compounds 1, 3 and 4 (each within the scatter of the next).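

In this assay the swap of methyl for trifluoromethyl can now be read directly: a 1.3-fold higher number from compound 3 to compound 4 (0.10 log units; within the scatter) stays within the scatter, so on this aromatic carbon, ortho to a large group, going from 1 heavy atom to 4 heavy atoms does not move the number beyond the usual variation. The change of trifluoromethyl to fluoro on an aromatic carbon reads the same way, with a 1.4-fold higher number from compound 1 to compound 4 (0.15 log units; within the scatter) also within the scatter, so compound 1, compound 3 and compound 4 cannot be told apart in this assay even though they carry different combinations of methyl, fluoro and trifluoromethyl. No measurement is available that would account for these steps.

Among the compounds shown here, the only step beyond the scatter remains a 5.8-fold higher number from compound 2 to compound 3 (0.76 log units; beyond the scatter) and it concerns a different change, so the three groups seen at this aromatic carbon do not show what would shift the number there. As far as these compounds go, whether an amine, a carboxylic acid or a longer chain such as propyl on this carbon would bring a step beyond the scatter remains open.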